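The source may hold more compounds than are shown below. What is called first, only, known or untested is meant among the compounds shown, and "the series" means these compounds.

Compound 1 `CCCCNC(=O)N1CC1C#N` and compound 2 `N#CC1CN1C(=O)Nc1ccc(F)cc1` share a core and differ in the group attached to the amide-type nitrogen. In a functional assay on OVCAR-3 cells (Homo sapiens) for inhibition (on this read-out higher numbers stand for weaker inhibition and lower numbers for stronger inhibition), compound 1 gives 12000 nM, the highest of the two numbers shown; compound 2 gives 5900 nM, a gap that lies beyond the usual scatter. Compound 3 `CNC(=O)N1CC1C#N` has not yet been measured; it differs from compound 1 by hydrogen in place of propyl on a saturated chain carbon bound to an amide-type nitrogen. Going by the values given here, no measured pair shows this change, so the direction rests on expectation alone: the step of a 1.7-fold higher number from compound 1 to compound 3 (0.22 log units; within the scatter) is expected to be modest and toward weaker inhibition. Compound 3 is therefore expected to give 20000 nM, with a plausible range from 6000 nM to 60000 nM.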

Compound 3, half-maximal inhibitory concentration: 14000 nM
Compound 3: the middle estimate sits 1.4-fold (0.15 log units) above what was measured, within the range that was stated.
By their numbers in this assay, from the lowest: compound 2; then compounds 1 and 3 (each within the scatter of the next).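

Going from butyl to methyl at this position gives a step (a 1.2-fold higher number from compound 1 to compound 3 (0.07 log units; within the scatter)) in this assay. Going by these compounds alone, this is the first measured pair for this change: hydrogen in place of propyl on a saturated chain carbon bound to an amide-type nitrogen leaves the read-out within the usual scatter. No supporting data on the compounds bear on this result.

On these data alone, whether a longer chain such as hexyl would behave the same way remains open. So does the effect of an amine or a carboxylic acid on this chain.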